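This account rests on a few compounds, and the source may have more. Where it says the series, first, only, none or still open, it means among the compounds named here.

Measured compounds in an assay on HEK293 cells for negative allosteric modulation of metabotropic glutamate receptor 5 (Homo sapiens), read by FLIPR, with a stated time of 1 h; on this read-out higher numbers stand for weaker inhibition and lower numbers for stronger inhibition:
compound 1 `O=C(C1CC12CCC2)N1CCc2nc(C#Cc3ccccc3)sc2C1` gives > 10000 nM, a limit of the assay.
compound 2 `O=C(C1CCCO1)N1CCc2nc(C#Cc3ccccc3)sc2C1` gives > 10000 nM, a limit of the assay.
compound 3 `CC1CCC(C(=O)N2CCc3nc(C#Cc4ccccc4)sc3C2)CC1` gives > 10000 nM, a limit of the assay.

Compound 3 stands only at a limit in this assay, so no number is known for it. The whole set sits at the limit of > 10000 nM in this assay, at which 3 of the 3 values shown sit, and every step between measured compounds is therefore unreadable: the step that the two limits leave unreadable from compound 1 to compound 2, the step that the two limits leave unreadable from compound 1 to compound 3 and the step that the two limits leave unreadable from compound 2 to compound 3 all change the group on the carbonyl carbon without revealing any size of effect.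

Compound 4 `N#Cc1cccc(C(=O)N2CCc3nc(C#Cc4ccccc4)sc3C2)c1` is not yet measured. The change from compound 3 is 3-cyanophenyl in place of 4-methylcyclohexyl on a carbonyl carbon. Among the compounds with values here, the steps that bear on it are those at the same carbonyl carbon, a step that the two limits leave unreadable from compound 2 to compound 3 and a step that the two limits leave unreadable from compound 1 to compound 3, and neither gives a readable size. From the measured series alone no direction can be derived for this assay, and a step of an at least 1.6-fold lower number from compound 3 to compound 4 (0.22 log units; that floor lies within the scatter) is expected only in the sense that the limit may again be all that is reported. Compound 4 is therefore estimated at 6000 nM, within 800 nM to 30000 nM, with a substantial chance that only a limit is returned.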

Compound 4, half-maximal inhibitory concentration: > 10000 nM
Compound 4: no number, only a limit; the forecaster's own chance of this, stated with the estimate: 55%; at least 1.6-fold (0.22 log units) between middle value and limit.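

In this assay compound 4 gives > 10000 nM as a limit of the assay and not a number. Within the data shown here, no step from compound 1, compound 2 or compound 3 to compound 4 can be read: the limit of > 10000 nM in this assay, at which 4 of the 4 values shown sit.

The compounds shown leave open whether any group on the carbonyl carbon gives a measurable inhibition, and how these groups would rank against one another.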